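Replacing the 2-nitrophenoxy group of compound 2

The compounds below may be only part of what the source reports. "The series", "measured", "known", "first", "only" and "open" are said of these compounds alone.

- compound 1 `CC(C)(Oc1ccc(F)cc1)C1OCC(C/C=C\CCC(=O)O)C(c2cccnc2)O1`: 120 nM
- compound 2 `CC(C)(Oc1ccccc1[N+](=O)[O-])C1OCC(C/C=C\CCC(=O)O)C(c2cccnc2)O1`: 11.2 nM

In a functional assay for inhibition, with Homo sapiens as the target (on this read-out higher numbers stand for weaker binding and lower numbers for tighter binding), compound 2 holds the lower of the two measured numbers, at 11.2 nM. Compound 3 `Cc1ccc(SC(C)(C)C2OCC(C/C=C\CCC(=O)O)C(c3cccnc3)O2)c([N+](=O)[O-])c1` keeps the shared core and differs from compound 2 in one place: a group of 11 heavy atoms (7 carbon, 1 nitrogen, 2 oxygen, 1 sulfur; one six-membered aromatic ring of carbon only) in place of a group of 10 heavy atoms (6 carbon, 1 nitrogen, 3 oxygen; one six-membered aromatic ring of carbon only), on a saturated chain carbon bound to two saturated chain carbons and a saturated ring carbon. Among the compounds with values here, one measured step bears on this change: an 11-fold lower number from compound 1 to compound 2 (1.03 log units; beyond the scatter). There, 2-nitrophenyl took the place of 4-fluorophenyl on an oxygen on a saturated carbon. Within the data shown here, that large step shows that the read-out can move strongly with changes in this part of the molecule, but no measured compound carries sulfur in this group, so the data give no direction. A much smaller step is therefore expected, probably none beyond the scatter. The estimated change is a 1.4-fold higher number from compound 2 to compound 3 (0.15 log units; within the scatter). Compound 3 is expected at 16 nM, with an estimated range from 4 nM to 60 nM.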

Compound 3, dissociation constant: 158 nM
Compound 3: middle estimate off by 9.9-fold (0.99 log units), on the low side; measured number outside the range, above it.
By their numbers in this assay, from the lowest: compound 2; then compounds 1 and 3 (each within the scatter of the next).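

The result shows that this position does not tolerate every close relative of the 2-nitrophenoxy group: in this assay the group of 11 heavy atoms with sulfur gives a 14-fold higher number from compound 2 to compound 3 (1.15 log units; beyond the scatter). The low number of compound 2 therefore does not carry over to a nitro-bearing aromatic ring as such, which the earlier pair could not show. The entering group also leaves the read-out level with the 4-fluorophenyl compound, with a 1.3-fold higher number from compound 1 to compound 3 (0.12 log units; within the scatter). Nothing at hand accounts for the size of this step.

The entering group differs from the 2-nitrophenoxy group in both its sulfur and its added methyl, so the compounds shown cannot say which of the two carries the step. On these data alone, how an amine nitrogen in place of that sulfur would read also remains open.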